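Putting an aromatic ring back on the amine of compound 2

This account rests on a few compounds, and the source may have more. Where it says the series, first, only, none or still open, it means among the compounds named here.

Compound 1 `O=C1C(Nc2ccc(I)cc2)=CC(=O)c2c1nc1n2[C@H]2OC[C@@H](O)[C@H]2OC1` gives 3890 nM as measured
Compound 2 `O=C1C(NC2CCCC2)=CC(=O)c2c1nc1n2[C@H]2OC[C@@H](O)[C@H]2OC1` gives > 16000 nM as a limit

Both entries come from a functional assay on MCF7 cells (Homo sapiens) for inhibition, read by sulforhodamine B assay (on this read-out lower numbers stand for stronger inhibition and higher numbers for weaker inhibition), and the entry for compound 2 is a limit of the assay, not a number. Compound 2 sits at the limit of > 16000 nM in this assay, at which 1 of the 2 values shown sits, and so has no exact value.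

Compound 3 `O=C1C(Nc2ccc(Br)cc2)=CC(=O)c2c1nc1n2[C@H]2OC[C@@H](O)[C@H]2OC1` has not been measured yet. Its difference from compound 2 is 4-bromophenyl in place of cyclopentyl on an amine nitrogen with 4-bromophenyl in place of cyclopentyl on an amine nitrogen. Among the measured compounds shown here, the one measured step that bears on this is an at least 4.1-fold higher number from compound 1 to compound 2 (0.61 log units; beyond the scatter) with cyclopentyl in place of 4-iodophenyl. Compound 1 gives 3890 nM with 4-iodophenyl in that place, so compound 3 is expected to fall near it, a move of similar size toward lower numbers. The estimated step is an at least 3.5-fold lower number from compound 2 to compound 3 (0.55 log units; beyond the scatter) toward lower numbers. For compound 3 the estimated value is 4500 nM with an expected range of 1800 nM to 11000 nM in this read-out.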

Compound 3, half-maximal inhibitory concentration: 4330 nM
Estimate against measurement, compound 3: 1.0-fold (0.02 log units) above; the range from low to high includes it.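

In this assay, 4-bromophenyl in place of cyclopentyl on the amine nitrogen gives an at least 3.6-fold lower number from compound 2 to compound 3 (0.56 log units; beyond the scatter), so the lower number seen with 4-iodophenyl does not rest on iodo alone. The entry for compound 2 is a limit of the assay and not a number: the limit of > 16000 nM in this assay, at which 1 of the 3 values shown sits. Bromo in place of iodo on the aromatic carbon gives a 1.1-fold higher number from compound 1 to compound 3 (0.05 log units; within the scatter), so in this assay these two halogens cannot be told apart at this place.

Going by these compounds, what stays open is whether a halogen is needed at all or whether the phenyl ring alone accounts for the step, which an unsubstituted phenyl or a phenyl carrying methoxy or an amine could test. On these data alone, it is also open whether a benzyl group on the same nitrogen would behave like the phenyl groups or like cyclopentyl.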